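Aryl changes and clearance on the shared core

The compounds below may be only part of what the source reports. "The series", "measured", "known", "first", "only" and "open" are said of these compounds alone.

compound 1 `Cc1ncc(C)n2nc(-c3ccn4cc(-c5ccc(F)cc5Cl)nc4n3)nc12` gives 11.5 mL.min-1.g-1
compound 2 `Cc1ncc(C)n2nc(-c3ccn4cc(-c5ccccc5)nc4n3)nc12` gives 5.6 mL.min-1.g-1
compound 3 `Cc1ncc(C)n2nc(-c3ccn4cc(-c5cccc(Cl)c5)nc4n3)nc12` gives 18.9 mL.min-1.g-1

In an ADME assay on microsomes from liver (Rattus norvegicus) for metabolic stability, read by LC-MS, in the presence of a further agent that is not named here (a lower number here means slower removal, a higher number faster removal of the compound), compound 3 (18.9 mL.min-1.g-1) cannot be separated from compound 1 (11.5 mL.min-1.g-1), as a 1.6-fold higher number from compound 1 to compound 3 (0.22 log units; within the scatter) shows. Compound 2 stands apart from both, with a 2.1-fold lower number from compound 1 to compound 2 (0.31 log units; beyond the scatter) on one side and a 3.4-fold higher number from compound 2 to compound 3 (0.53 log units; beyond the scatter) on the other.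

Compound 4 `COc1ccccc1-c1cn2ccc(-c3nc4c(C)ncc(C)n4n3)nc2n1` is still unmeasured. It carries 2-methoxyphenyl in place of 3-chlorophenyl on an aromatic carbon and so loses the chloro group. Among the measured compounds shown here, no measured compound holds a methoxy group, so the evidence is indirect. The three measured aryl changes were modest or within the scatter, and the values of compound 1 and compound 3 show that a chloro group alone does not fix the number. Only a small move in this assay is expected, slightly downward if any, and the expected step is a 1.4-fold lower number from compound 3 to compound 4 (0.13 log units; within the scatter) and not clearly beyond the scatter. The estimated value for compound 4 is 14 mL.min-1.g-1 (expected range 6 mL.min-1.g-1 to 32 mL.min-1.g-1).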

Compound 4, intrinsic clearance in microsomes: 9.1 mL.min-1.g-1
Compound 4: the middle estimate sits 1.5-fold (0.19 log units) above what was measured; the measured number falls inside the stated range.
By their numbers in this assay, from the lowest: compounds 2, 4, 1 and 3 (each within the scatter of the next, the first and the last beyond it).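

In this assay, 2-methoxyphenyl on the aromatic carbon of the five-membered ring gives a number that separates from the 3-chlorophenyl result (a 2.1-fold lower number from compound 3 to compound 4 (0.32 log units; beyond the scatter)). The same group cannot be separated from plain phenyl (a 1.6-fold higher number from compound 2 to compound 4 (0.21 log units; within the scatter)) or from 2-chloro-4-fluorophenyl (a 1.3-fold lower number from compound 1 to compound 4 (0.10 log units; within the scatter)), so an aryl group with a hydrogen-bond acceptor stays within the scatter of two of the earlier aryl groups. Nothing available here accounts for these steps.

As far as these compounds go, whether the step from 3-chlorophenyl follows from the change of group or from where the group sits on the phenyl ring remains open; a 3-methoxyphenyl or 2-chlorophenyl group would be needed to tell these apart. Also open, from the compounds shown here alone, is how the number responds when the aryl group carries an amine or a carboxylic acid.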